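Swapping phenyl for thiophen-2-yl on compound 1

This account rests on a few compounds, and the source may have more. Where it says the series, first, only, none or still open, it means among the compounds named here.

- Compound 1 `c1ccc(-c2cc(-c3cccnc3)nc(-c3ccccn3)c2)cc1` gives 89.2 ug/mL
- Compound 2 `c1ccc(-c2cc(-c3ccccn3)nc(-c3ccccn3)c2)cc1` gives 7.5 ug/mL
- Compound 3 `c1ccc(-c2cc(-c3ccoc3)cc(-c3ccccn3)n2)nc1` gives 0.33 ug/mL

In a functional assay on SK-MEL-2 cells (Homo sapiens) for antiproliferative activity (a lower number here means a stronger inhibitor of growth, a higher number a weaker inhibitor of growth), compound 1 has the highest number of the three and is the weakest inhibitor of growth among them, with compound 2 nearest and compound 3 furthest. The next compound, compound 4 `c1ccc(-c2cc(-c3cccs3)cc(-c3cccnc3)n2)nc1`, keeps the pyridin-3-yl group of compound 1 and carries thiophen-2-yl in place of phenyl on an aromatic carbon.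

Within the data shown here, the closest precedent is a 23-fold lower number from compound 2 to compound 3 (1.36 log units; beyond the scatter), which came with furan-3-yl in place of phenyl at the same place. Among the measured compounds shown here, that step was measured with pyridin-2-yl present, and no compound yet carries thiophen-2-yl. The other step, a 12-fold lower number from compound 1 to compound 2 (1.08 log units; beyond the scatter), came with pyridin-2-yl in place of pyridin-3-yl, a change that compound 4 does not make. A large move to a lower number in this assay is therefore expected, though probably somewhat smaller than the furan-3-yl step. The expected change is a 9.9-fold lower number from compound 1 to compound 4 (1.00 log units; beyond the scatter). The estimate for compound 4 is 9 ug/mL, with an expected range from 2 ug/mL to 40 ug/mL.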

Compound 4, concentration for 50% growth inhibition: 77.7 ug/mL
Compound 4: the middle estimate sits 8.6-fold (0.94 log units) below what was measured; measured number above the stated range.
By their numbers in this assay, from the lowest: compound 3; then compound 2; then compounds 4 and 1 (each within the scatter of the next).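

With pyridin-3-yl present, the carbon opposite the ring nitrogen takes thiophen-2-yl in place of phenyl with a 1.1-fold lower number from compound 1 to compound 4 (0.06 log units; within the scatter) in this assay, so this exchange does not separate the two compounds. The large step seen earlier, a 23-fold lower number from compound 2 to compound 3 (1.36 log units; beyond the scatter), therefore does not extend to every five-membered aromatic ring at this position, although that step involved furan-3-yl with pyridin-2-yl present, and compound 4 carries neither group. Nothing measured here explains why the two exchanges read so differently.

Going by these compounds, it remains open whether thiophen-2-yl would give a larger step with pyridin-2-yl present, and whether furan-3-yl would keep its step with pyridin-3-yl present. Also open, on these data alone, is how an amine or a carboxylic acid on this carbon would read in this assay.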